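The source may report more compounds than this note shows. Statements on the series, on what has been measured and on what is new or still open speak of the compounds shown alone.

Measured so far:
compound 1 `COc1ccc(/C=N/NC(=O)c2ccc(C)cc2O)cc1` — > 100000 nM
compound 2 `Cc1ccc(C(=O)N/N=C/c2ccc(Cl)cc2)c(O)c1` — 12300 nM

Among the compounds with values here, of the two values shown, compound 2 holds the only number: in a functional assay (Mus musculus, strain BALB/C) for inhibition, read by MTT assay, with stated times of 24 h and 72 h (on this read-out higher numbers stand for weaker inhibition and lower numbers for stronger inhibition), compound 2 gives 12300 nM. Compound 1 reaches in this assay only the limit > 100000 nM, which is not a number (the limit of > 100000 nM in this assay, at which 1 of the 2 values shown sits). Within the data shown here, the single measured step, an at least 8.1-fold lower number from compound 1 to compound 2 (0.91 log units; beyond the scatter), is the only comparison in the set.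

Compound 3 `Cc1ccc(C(=O)N/N=C/c2ccc(F)cc2)c(O)c1` differs from compound 2 by fluoro in place of chloro on an aromatic carbon. No measured step exchanges one halogen for another, so the one step shown bears on this change only loosely; it sets the scale of what a change at this position can do, not its direction here. A step of modest size toward a higher number, or none beyond the scatter, is expected: a 2.0-fold higher number from compound 2 to compound 3 (0.31 log units; beyond the scatter). Compound 3 is therefore estimated at 25000 nM, with a range from 8000 nM to 100000 nM.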

Compound 3, half-maximal inhibitory concentration: 26700 nM
Compound 3: the middle estimate sits 1.1-fold (0.03 log units) below what was measured, and the stated range covers the measured number.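

In this assay, the two halogens are not interchangeable at this position, para to a large group: the exchange gives a 2.2-fold higher number from compound 2 to compound 3 (0.34 log units; beyond the scatter). Fluoro, like chloro, still yields a measured number where methoxy does not, with an at least 3.7-fold lower number from compound 1 to compound 3 (0.57 log units; beyond the scatter), so the three compounds shown order as chloro, then fluoro, then methoxy toward higher numbers. Compound 1 stands at a limit and not a number, so the size of its steps remains a bound only: the limit of > 100000 nM in this assay, at which 1 of the 3 values shown sits.

On these data alone, whether a bromo, an amine or a carboxylic acid at this same place would fall in line with chloro and fluoro stays open. The compounds shown differ only at this place, so the effect of any change elsewhere on the shared core also stays open.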